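The source may report more compounds than this note shows. Statements on the series, on what has been measured and on what is new or still open speak of the compounds shown alone.

Compound 1 `N#CC1=C(N)Oc2c(N)cc3nc4ccccc4nc3c2C12C(=O)N(Cc1cnnn1-c1cccc(Br)c1)c1ccccc12` sits at the limit of a functional assay on MCF7 cells (Homo sapiens) for antiproliferative activity, read by MTT assay, with a stated time of 48 h (a higher number here means a weaker inhibitor, a lower number a stronger inhibitor), giving > 50000 nM.
Compound 2 `N#CC1=C(N)Oc2c(N)cc3nc4ccccc4nc3c2C12C(=O)N(Cc1cnnn1-c1ccccc1Br)c1ccccc12` gives a number in this assay, 30700 nM.
Compound 3 `Cc1ccc(-n2nncc2CN2C(=O)C3(C(C#N)=C(N)Oc4c(N)cc5nc6ccccc6nc5c43)c3ccccc32)cc1C` likewise sits at the limit, > 50000 nM.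

Compound 3 therefore stands only as a limit, sharing it with compound 1 (the limit of > 50000 nM in this assay, at which 2 of the 3 values shown sit); compound 2 alone yields a number, and its steps to the two limits are floors within the scatter. Compound 4 `N#CC1=C(N)Oc2c(N)cc3nc4ccccc4nc3c2C12C(=O)N(Cc1cnnn1-c1ccc([N+](=O)[O-])cc1[N+](=O)[O-])c1ccccc12` differs from compound 3 by 2,4-dinitrophenyl in place of 3,4-dimethylphenyl on an aromatic nitrogen. All measured steps change the same aryl group on the aromatic nitrogen: an at least 1.6-fold lower number from compound 1 to compound 2 (0.21 log units; that floor lies within the scatter), a step that the two limits leave unreadable from compound 1 to compound 3, an at least 1.6-fold higher number from compound 2 to compound 3 (0.21 log units; that floor lies within the scatter). Where readable, none moves the number beyond the scatter, so no step beyond the scatter is expected, a number no higher from compound 3 to compound 4 (the limit leaves the size open). Compound 4 is expected to give about 50000 nM, between 25000 nM and 100000 nM, most likely again reported only as a limit.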

Compound 4, half-maximal inhibitory concentration: 20900 nM
Compound 4: the middle estimate sits 2.4-fold (0.38 log units) above what was measured; the whole stated range lies above it.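

For the compounds shown here, on the aromatic nitrogen, 2,4-dinitrophenyl gives the first steps in this assay that pass the scatter: an at least 2.3-fold lower number from compound 3 to compound 4 (0.37 log units; beyond the scatter) and an at least 2.3-fold lower number from compound 1 to compound 4 (0.37 log units; beyond the scatter). Against 2-bromophenyl there is no such separation, a 1.5-fold lower number from compound 2 to compound 4 (0.17 log units; within the scatter), and only compound 2 and compound 4 give readable numbers, while compound 1 and compound 3 do not. Both larger steps start from a limit, so their sizes are floors: the limit of > 50000 nM in this assay, at which 2 of the 4 values shown sit.

Still open, going by these compounds, is whether a single nitro group at this place would match 2,4-dinitrophenyl. Also open, on these data alone, is how a phenyl bearing an amine or a carboxylic acid would read here.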